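The source may hold more compounds than are shown below. What is called first, only, known or untested is meant among the compounds shown, and "the series" means these compounds.

Measured compounds in an in vitro assay on SH-SY5Y cells for displacement of a labelled ligand from Neuronal acetylcholine receptor; alpha3/beta4 (Homo sapiens); a lower number here means a stronger inhibitor, a higher number a weaker inhibitor:
compound 1, `Fc1ccc(C2=CC3CNCC(C2)C3)cn1`, gives 28 nM
compound 2, `C1=C(c2ccncc2)CC2CNCC1C2`, gives 459 nM

Compound 1 has the lowest number of the two; the gap from compound 2 to compound 1 is beyond the usual scatter of this assay, so compound 1 is the stronger binder of the pair on the values in hand. No change from a measured compound to another measured compound is available that differs in one place, so the step to compound 3 cannot be set against a precedent of the same kind.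

Compound 3, `C1=C(c2cccnc2)CC2CNCC1C2`, differs from compound 1 as follows: hydrogen in place of fluoro on an aromatic carbon.

Without a precedent, the expectation for this assay is a small weakening, most likely within the scatter and at most a little beyond it, so the step from compound 1 to compound 3 is estimated at a 2.1-fold higher number from compound 1 to compound 3 (0.33 log units; beyond the scatter). Compound 3 is therefore expected to give 60 nM in this assay, with a range from 20 nM to 200 nM.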

Compound 3, inhibition constant: 12 nM
Beside the measured number, compound 3's estimate is 5.0-fold (0.70 log units) above it, and the stated range ends above it.
By their numbers in this assay, from the lowest: compound 3; then compound 1; then compound 2.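

Hydrogen in place of fluoro on the aromatic carbon next to the ring nitrogen gives a 2.3-fold lower number from compound 1 to compound 3 (0.37 log units; beyond the scatter) in this assay. This modest step, beyond the scatter, shows that the fluoro group is not needed for binding at this position, and that on these values hydrogen is the better of the two groups there. Going by these compounds alone, it is also the first one-place step, giving this position a measured direction that the earlier pair could not supply, though no measurement on hand accounts for that direction.

From the compounds shown here alone, only hydrogen and fluoro can be compared at this position, so it stays open whether chloro, methyl, methoxy or an amine on this carbon would give a lower or a higher number. Going by these compounds, whether fluoro on the other aromatic carbons of this ring would behave in the same way also stays open.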